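The compounds below may be only part of what the source reports. "The series", "measured", "known", "first", "only" and "open" are said of these compounds alone.

Working notes on the series. Compound 1 `CN1CCN(c2nc(-c3cccc(Cl)c3)nc3[nH]cnc23)CC1` and compound 2 `CN1CCN(c2nc(-c3cccc(O)c3)nc3[nH]cnc23)CC1` share one core and differ in a single place. In an assay on cells for displacement of a labelled ligand from adenosine receptor A1 (Homo sapiens), read by scintillation counting and radioligand binding, with a stated time of 60 min, tested at 10 uM (on this read-out higher numbers stand for more inhibition at the one concentration tested (going by the name of the read-out) and lower numbers for less inhibition), compound 1 gives > 80%, which is a limit of the assay and not a number. In this assay compound 2 gives > 80%, again a limit rather than a number. Among the compounds with values here, the only measured step is a step that the two limits leave unreadable from compound 1 to compound 2; its size cannot be read, because both ends sit at the limit of > 80% in this assay, at which 2 of the 2 values shown sit. Compound 2 therefore stands at the upper limit of what was measured, with no readable distance from compound 1.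

Compound 3 `CN1CCN(c2nc(-c3ccc(Cl)cc3)nc3[nH]cnc23)CC1` is not yet measured. It differs from compound 2 by 4-chlorophenyl in place of 3-hydroxyphenyl on an aromatic carbon. The step that the two limits leave unreadable from compound 1 to compound 2 is the only one that bears on this change, since it also exchanges chloro against hydroxy, but it leaves no size to carry over. With both known values at the limit, compound 3 is expected to give 88% in this assay, with a range from 75% to 99%. The expected step is a step that the limit leaves unreadable from compound 2 to compound 3, that is, none beyond the scatter, and the most likely outcome for compound 3 is another reading at the limit.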

Compound 3, a percentage reported as inhibition, at one concentration (the size of the read-out at that concentration, not a potency): > 80%
Compound 3: no number, only a limit; the forecaster's own chance of this, stated with the estimate: 70%; the middle value lies beyond the limit too.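

In this assay compound 3 gives > 80%, which is a limit and not a number. No new step can be read between compound 3 and either compound 1 or compound 2: the limit of > 80% in this assay, at which 3 of the 3 values shown sit.

The compounds shown leave open whether 3-chlorophenyl, 3-hydroxyphenyl and 4-chlorophenyl on the shared core differ at all in this assay.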